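This account rests on a few compounds, and the source may have more. Where it says the series, first, only, none or still open, it means among the compounds named here.

Three compounds have so far been measured in an ADME assay (liver) for metabolic stability, with Liver microsome (Homo sapiens) as the target, using microsomes and NADPH, with a stated time of 30 min, tested at 1 uM; on this read-out higher numbers stand for fast clearance and lower numbers for slow clearance:

Compound 1, `CC(C)n1cc(-c2cc(C(O)(C(F)(F)F)C(F)(F)F)cnc2N2CCN(S(=O)(=O)c3ccc(N)nc3)CC2)cn1`, gives 38 mL.min-1.g-1.
Compound 2, `Cc1csc(-c2cc(C(O)(C(F)(F)F)C(F)(F)F)cnc2N2CCN(S(=O)(=O)c3ccc(N)nc3)CC2)c1`, gives 29 mL.min-1.g-1.
Compound 3, `CS(=O)(=O)c1ccc(-c2cc(C(O)(C(F)(F)F)C(F)(F)F)cnc2N2CCN(S(=O)(=O)c3ccc(N)nc3)CC2)cc1`, gives 32 mL.min-1.g-1.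

All three share one core and differ only in the group attached at a single aromatic carbon. Compound 3 holds the second highest of the three numbers, yet its distances to both neighbours are small: a 1.1-fold higher number from compound 2 to compound 3 (0.04 log units; within the scatter), and a 1.2-fold lower number from compound 1 to compound 3 (0.07 log units; within the scatter). The remaining pair behaves the same way, a 1.3-fold lower number from compound 1 to compound 2 (0.12 log units; within the scatter). Swapping the group at this carbon has therefore produced nothing beyond the scatter among these three.

Compound 4, `Nc1ccc(S(=O)(=O)N2CCN(c3ncc(C(O)(C(F)(F)F)C(F)(F)F)cc3-c3cc4ccccc4s3)CC2)cn1`, has not yet been measured. It differs from compound 3 in one place: 1-benzothiophen-2-yl in place of 4-(methylsulfonyl)phenyl on an aromatic carbon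

Every measured step bears on this change, because each of a 1.3-fold lower number from compound 1 to compound 2 (0.12 log units; within the scatter), a 1.2-fold lower number from compound 1 to compound 3 (0.07 log units; within the scatter) and a 1.1-fold higher number from compound 2 to compound 3 (0.04 log units; within the scatter) was a swap of the group at the same aromatic carbon and each stayed within the scatter. The expectation is accordingly that compound 4 shows no step beyond the scatter, a 1.3-fold higher number from compound 3 to compound 4 (0.10 log units; within the scatter). Compound 4 is estimated to give 40 mL.min-1.g-1, with a range from 22 mL.min-1.g-1 to 75 mL.min-1.g-1.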

Compound 4, intrinsic clearance in microsomes: < 14 mL.min-1.g-1
Compound 4 was reported as a limit (the forecaster's own chance of this, stated with the estimate: 5%); middle value at least 2.8-fold (0.45 log units) from the limit.
By their numbers in this assay, from the lowest: compounds 2, 3 and 1 (each within the scatter of the next). At a limit, below all of these: compound 4.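

In this assay compound 4 is reported as a limit and not as a number: the limit of < 14 mL.min-1.g-1 in this assay, at which 1 of the 4 values shown sits. This shows that a swap at this aromatic carbon, two atoms from the ring nitrogen, can move the read-out beyond the scatter, which none of the earlier swaps did: the change gives an at least 2.2-fold lower number from compound 3 to compound 4 (0.35 log units; beyond the scatter), an at least 2.0-fold lower number from compound 2 to compound 4 (0.31 log units; beyond the scatter) and an at least 2.7-fold lower number from compound 1 to compound 4 (0.43 log units; beyond the scatter). All three steps point towards slower clearance, and the step from compound 3 comes with a change from a single six-membered aromatic ring to a five-membered and a six-membered aromatic ring, although the entering 1-benzothiophen-2-yl group has fewer heavy atoms than the leaving 4-(methylsulfonyl)phenyl group.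

On these data alone, how far below the limit compound 4 really lies remains open, so the full size of these steps cannot be stated. The compounds shown also do not separate the roles of the sulfur and the six-membered ring of 1-benzothiophen-2-yl, a question on which a 1-benzofuran-2-yl group, with oxygen in place of sulfur, or a naphthalen-2-yl group at the same carbon would bear.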